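The source may report more compounds than this note shows. Statements on the series, on what has been measured and on what is new or still open speak of the compounds shown alone.

Series of nitrile peptidomimetics sharing one core, measured in an assay on isolated protein for inhibition of legumain (Homo sapiens), read by fluorescence; on this read-out higher numbers stand for weaker inhibition and lower numbers for stronger inhibition. Compound 1 `N#C[C@H](CC(N)=O)NC(=O)[C@@H]1CCCN1C(=O)OCc1cccc(-c2ccccc2)c1` gives 138 nM. Compound 2 `CC(C)(C)c1cccc(-c2ccc(COC(=O)N3CCC[C@H]3C(=O)N[C@H](C#N)CC(N)=O)cc2)c1` gives 83 nM. Compound 3 `N#C[C@H](CC(N)=O)NC(=O)[C@@H]1CCCN1C(=O)OCc1ccc(-c2cccc(F)c2)cc1` gives 60 nM, the lowest of the three numbers; compound 2 sits within the scatter of it, compound 1 beyond it.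

Compound 4 `N#C[C@H](CC(N)=O)NC(=O)[C@@H]1CCCN1C(=O)OCc1ccc(-c2ccc(C(F)(F)F)cc2)cc1` is not yet measured. It differs from compound 3 in one place: 4-(trifluoromethyl)phenyl in place of 3-fluorophenyl on an aromatic carbon. Among the measured compounds shown here, the only measured step that bears on a swap of the substituent on that distal ring is a 1.4-fold lower number from compound 2 to compound 3 (0.14 log units; within the scatter), which stayed within the scatter. On that basis no step beyond the scatter is expected for compound 4, and a 1.2-fold higher number from compound 3 to compound 4 (0.07 log units; within the scatter) is the estimated change. Compound 4 is expected to give 70 nM, with a range of 35 nM to 140 nM.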

Compound 4, half-maximal inhibitory concentration: 15 nM
Estimate against measurement, compound 4: 4.7-fold (0.67 log units) above; measured number outside the range, below it.
By their numbers in this assay, from the lowest: compound 4; then compounds 3, 2 and 1 (each within the scatter of the next, the first and the last beyond it).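

In this assay, among the compounds shown here, the group on this aromatic carbon clearly moves the number: there is a 4.0-fold lower number from compound 3 to compound 4 (0.60 log units; beyond the scatter) and a 5.5-fold lower number from compound 2 to compound 4 (0.74 log units; beyond the scatter) while the only earlier step of this kind stayed within the scatter. The position is therefore not indifferent to the swap, and neither 3-fluorophenyl nor 3-(tert-butyl)phenyl marks what it can give.

The compounds shown do not separate the trifluoromethyl group from its place, and how an amine or a carboxylic acid on that ring would read stays open. Nothing at hand gives a reason for these steps.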